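Working notes: difluoromethyl for isopropyl, compound 2 to compound 3

The source may report more compounds than this note shows. Statements on the series, on what has been measured and on what is new or still open speak of the compounds shown alone.

Compound 1 `Fc1ccc2nc(-c3cncnc3)n(C3CC3)c2c1` and compound 2 `CC(C)c1ncncc1-c1nc2cc(F)c(F)cc2n1C1CC1` have been run in an ADME assay on cells for inhibition of cytochrome P450 11B1, mitochondrial (Homo sapiens), read by HPLC, with a stated time of 60 min; on this read-out higher numbers stand for weaker inhibition and lower numbers for stronger inhibition. Compound 1 gives 5380 nM, and compound 2 gives 1910 nM, the lower of the two numbers, with a gap to compound 1 that lies beyond the usual scatter. Compound 3 `Fc1cc2nc(-c3cncnc3C(F)F)n(C3CC3)c2cc1F` is not yet measured; it differs from compound 2 by difluoromethyl in place of isopropyl on an aromatic carbon. For the measured compounds named here, no measured step of this kind exists, so the change is expected to stay close to the scatter, leaning toward a weaker number if anything. Compound 3 is expected to give 2600 nM, within a range from 900 nM to 7500 nM, which amounts to an expected step of a 1.4-fold higher number from compound 2 to compound 3 (0.13 log units; within the scatter).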

Compound 3, half-maximal inhibitory concentration: 4330 nM
The estimate for compound 3 lay 1.7-fold (0.22 log units) below the measured number; the measured number falls inside the stated range.
By their numbers in this assay, from the lowest: compound 2; then compounds 3 and 1 (each within the scatter of the next).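

In this assay, difluoromethyl in place of isopropyl on the aromatic carbon next to the ring nitrogen gives a 2.3-fold higher number from compound 2 to compound 3 (0.36 log units; beyond the scatter) as a modest step beyond the scatter. This position therefore responds to the group it carries, even though the two groups have the same heavy-atom count and neither has hydrogen-bond donors or acceptors. Nothing measured here explains the step.

Still open, going by these compounds, is how an amine or a methoxy group would read at this carbon. Also open, on these data alone, is whether the step would hold with a different fluorine pattern on the shared core.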